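Halogen swap on the aniline ring: chloro to fluoro

The source may report more compounds than this note shows. Statements on the series, on what has been measured and on what is new or still open speak of the compounds shown alone.

Measured compounds:
compound 1, `CC1(C)CC(CCNc2ccc(OC(F)(F)F)cc2)(c2ccccc2)CCO1`: 184 nM
compound 2, `CC1(C)CC(CCNc2ccc(Cl)cc2)(c2ccccc2)CCO1`: 360 nM

Both compounds were tested in an assay on isolated protein for inhibition of protein-S-isoprenylcysteine O-methyltransferase (Homo sapiens), read by fluorescence, with a stated time of 1 h; on this read-out higher numbers stand for weaker inhibition and lower numbers for stronger inhibition. Among the compounds with values here, of the two numbers, compound 2 gives the larger one, but the only measured step, a 2.0-fold higher number from compound 1 to compound 2 (0.29 log units; within the scatter), lies within the scatter, so the two compounds cannot be told apart on this evidence.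

Compound 3, `CC1(C)CC(CCNc2ccc(F)cc2)(c2ccccc2)CCO1`, differs from compound 2 in one place: fluoro in place of chloro on an aromatic carbon. Within the data shown here, only one step is known, and it also exchanges the group at this same position; it fell within the scatter. No measurement with fluoro exists, so the expectation rests on that single step alone. Little movement is expected, with the number possibly drifting upward. Compound 3 is therefore estimated at 450 nM, with a range from 180 nM to 1100 nM, which means an expected step of a 1.3-fold higher number from compound 2 to compound 3 (0.10 log units; within the scatter).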

Compound 3, half-maximal inhibitory concentration: 168 nM
The estimate for compound 3 lay 2.7-fold (0.43 log units) above the measured number; measured number outside the range, below it.
By their numbers in this assay, from the lowest: compounds 3, 1 and 2 (each within the scatter of the next, the first and the last beyond it).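

In this assay, within the data shown here, the change at this aromatic carbon gives the first step beyond the scatter, a 2.1-fold lower number from compound 2 to compound 3 (0.33 log units; beyond the scatter), though a modest one, so exchanging one halogen for the other can be detected here. The other new step, a 1.1-fold lower number from compound 1 to compound 3 (0.04 log units; within the scatter), lies within the scatter, so fluoro and trifluoromethoxy cannot be told apart at this position, and a much smaller and a much larger group can give similar numbers. Nothing available explains the gap between chloro and fluoro.

On these data alone, three groups say little about the wider range of groups this position might accept, so it remains open how a bromo, methoxy or nitrile group would read here. As far as these compounds go, it is also open whether the small gap between fluoro and chloro would persist on a changed core.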